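Swapping cyclohexylmethyl for 2-phenylethenyl on a carbonyl carbon

The source may report more compounds than this note shows. Statements on the series, on what has been measured and on what is new or still open speak of the compounds shown alone.

Within the data shown here, in an in vivo functional assay on the whole organism (MDA-MB-435 cells, Homo sapiens) for antiproliferative activity (a higher number here means a weaker inhibitor, a lower number a stronger inhibitor), compound 1 `CO[C@@H](C(=O)NC1CC[C@@H](OC(=O)CC2CCCCC2)CNC1=O)[C@H](O)[C@@H](O)[C@H](O)/C=C/C(C)(C)C` gives 60 nM and this is the only actual number so far. Compound 2 `CCCCCCCCCCCCCC(=O)O[C@@H]1CCC(NC(=O)[C@H](OC)[C@H](O)[C@@H](O)[C@H](O)/C=C/C(C)(C)C)C(=O)NC1` gives < 10 nM and that value is a limit of the assay, not a number. Among the measured compounds shown here, the single measured step that bears on the question is an at least 6.0-fold lower number from compound 1 to compound 2 (0.77 log units; beyond the scatter) and it lies beyond the scatter. That step is dodecyl in place of cyclohexyl on a saturated chain carbon bound to a carbonyl carbon.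

Compound 3 `CO[C@@H](C(=O)NC1CC[C@@H](OC(=O)/C=C/c2ccccc2)CNC1=O)[C@H](O)[C@@H](O)[C@H](O)/C=C/C(C)(C)C` differs from compound 1 in another way 2-phenylethenyl in place of cyclohexylmethyl on a carbonyl carbon with 2-phenylethenyl in place of cyclohexylmethyl on a carbonyl carbon. The group that leaves and the group that enters each hold one six-membered ring, and neither is a long chain like the dodecyl of compound 2. The measured step therefore offers only loose guidance, and the expectation stays close to compound 1 at 60 nM in this assay with no shift beyond the scatter. The estimated change is a 1.3-fold higher number from compound 1 to compound 3 (0.12 log units; within the scatter) and it points slightly towards a higher number. For compound 3 the estimated value is 80 nM with an expected range from 25 nM to 250 nM once it is measured.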

Compound 3, half-maximal inhibitory concentration: 20 nM
Compound 3: the middle estimate sits 4.0-fold (0.60 log units) above what was measured; the measured number lies below the stated range.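

In this assay, putting 2-phenylethenyl in place of cyclohexylmethyl on the carbonyl carbon gives a 3.0-fold lower number from compound 1 to compound 3 (0.48 log units; beyond the scatter). Among these compounds, until now the only step at this place was the one to the long chain, an at least 6.0-fold lower number from compound 1 to compound 2 (0.77 log units; beyond the scatter), so the lower number could have been tied to the dodecyl group alone. The new step shows that this place also responds to a group with no long chain, one that still holds a single six-membered ring, now aromatic, and adds one double bond outside that ring.

Because the aromatic ring and the double bond enter together, the compounds shown do not say which of them goes with the lower number, and a 2-phenylethyl or a plain phenyl group on the same carbonyl carbon would separate the two. The value of compound 2 is a limit of the assay and not a number, so how far a long chain can lower the number at this place stays open: the limit of < 10 nM in this assay, at which 1 of the 3 values shown sits.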